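The compounds below may be only part of what the source reports. "The series", "measured", "known", "first", "only" and "open" are said of these compounds alone.

Compound 3 `COc1ccc(S(=O)(=O)c2n[nH]c3cc(N4CCNCC4)ccc23)cc1` gives 124 nM in an assay on HeLa cells for displacement of a labelled ligand from 5-hydroxytryptamine receptor 6 (Homo sapiens) (on this read-out lower numbers stand for stronger inhibition and higher numbers for weaker inhibition), the highest of the three numbers available. Its nearest neighbour is compound 1 `O=S(=O)(c1ccc(Cl)cc1)c1n[nH]c2cc(N3CCNCC3)ccc12`, which in this assay gives 110 nM; the step of a 1.1-fold higher number from compound 1 to compound 3 (0.05 log units; within the scatter) lies within the scatter. Furthest away is compound 2 `CN1CCN(c2cccc3c(S(=O)(=O)c4cccc5ccccc45)n[nH]c23)CC1`, which in this assay gives 4.6 nM, a markedly lower number, but compound 2 differs from compound 3 in more than one place, so no single step connects the two and only the two values can be compared.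

Compound 4 `Cc1ccc(S(=O)(=O)c2n[nH]c3cc(N4CCNCC4)ccc23)cc1` arises from compound 3 by methyl in place of methoxy on an aromatic carbon. Among the measured compounds shown here, the one measured step that bears on this change is a 1.1-fold higher number from compound 1 to compound 3 (0.05 log units; within the scatter), in which one small group on the same aromatic carbon was exchanged for another and the number did not move beyond the scatter. On that basis the exchange of methoxy for methyl is expected to behave alike, and the expected step of a 1.1-fold lower number from compound 3 to compound 4 (0.05 log units; within the scatter) is one that stays within the scatter. For compound 4 the estimated value in this assay is 110 nM, with a range from 50 nM to 250 nM.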

Compound 4, inhibition constant: 27 nM
Estimate against measurement, compound 4: 4.1-fold (0.61 log units) above; the whole stated range lies above it.
By their numbers in this assay, from the lowest: compound 2; then compound 4; then compounds 1 and 3 (each within the scatter of the next).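

At this aromatic carbon, para to a large group, the exchange of one group for another can matter in this assay: methyl gives a lower number than methoxy (a 4.6-fold lower number from compound 3 to compound 4 (0.66 log units; beyond the scatter)) and also a lower number than chloro (a 4.1-fold lower number from compound 1 to compound 4 (0.61 log units; beyond the scatter)), both steps beyond the scatter. The earlier step (a 1.1-fold higher number from compound 1 to compound 3 (0.05 log units; within the scatter)) lay within the scatter, so the likeness of chloro and methoxy at this place does not extend to methyl, and among these three compounds methyl alone stands apart. Nothing given here accounts for this difference between methyl and the other two groups.

On these data alone, whether the lower number belongs to methyl alone remains open, since an ethyl group, a longer chain, or an amine on the same carbon would show whether it extends beyond this one group. As far as these compounds go, it is also open whether methyl would give a step of similar size on a differently substituted core, such as that of compound 2, or at another carbon of the same aromatic ring.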